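This account rests on a few compounds, and the source may have more. Where it says the series, first, only, none or still open, it means among the compounds named here.

Among the measured compounds shown here, in an ADME assay on HEK293 cells for displacement of a labelled ligand from 5-hydroxytryptamine receptor 7 (Homo sapiens), read by radioligand binding, with a stated time of 1 h (a lower number here means a stronger inhibitor, a higher number a weaker inhibitor), compound 3 `O=C1c2ccccc2S(=O)(=O)N1CCCCCCN1CCN(c2cccc3ccccc23)CC1` gives 20 nM, the lowest of the three numbers measured so far. Compound 2 `O=C1c2ccccc2S(=O)(=O)N1CCCCCCN1CCN(c2cccc(C(F)(F)F)c2)CC1` gives 58 nM and compound 1 `O=C1c2ccccc2S(=O)(=O)N1CCCCCCN1CCN(c2ccc(Cl)c(Cl)c2)CC1` gives 258 nM. Both neighbours differ from compound 3 only in the group on the ring amine nitrogen, and the steps toward compound 3 were a 2.9-fold lower number from compound 2 to compound 3 (0.46 log units; beyond the scatter) and a 13-fold lower number from compound 1 to compound 3 (1.11 log units; beyond the scatter), so the naphthalen-1-yl group stands clearly lowest of the three groups tried at this place. Compound 4 `O=C1c2ccccc2S(=O)(=O)N1CCCCCCN1CCN(c2ccccn2)CC1` changes the same place: pyridin-2-yl in place of naphthalen-1-yl on an amine nitrogen in a ring. For the measured compounds named here, no measured step shows what a pyridin-2-yl group does here. The two measured steps bear on it only in size: each single-ring group tried at this place gave a number a modest to large amount higher than naphthalen-1-yl, and pyridin-2-yl is another single-ring group of fewer heavy atoms. A rise in this assay of modest to large size is therefore expected, an 11-fold higher number from compound 3 to compound 4 (1.04 log units; beyond the scatter). Compound 4 is expected near 220 nM, within 60 nM to 800 nM.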

Compound 4, inhibition constant: 552 nM
Compound 4: the middle estimate sits 2.5-fold (0.40 log units) below what was measured, and the stated range covers the measured number.
By their numbers in this assay, from the lowest: compound 3; then compound 2; then compound 1; then compound 4.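

In this assay, pyridin-2-yl gives the highest number of the four groups tried on the amine nitrogen in a ring, with steps of (a 28-fold higher number from compound 3 to compound 4 (1.44 log units; beyond the scatter)), (a 9.5-fold higher number from compound 2 to compound 4 (0.98 log units; beyond the scatter)) and (a 2.1-fold higher number from compound 1 to compound 4 (0.33 log units; beyond the scatter)). The earlier compounds shown here showed single-ring groups only as higher than naphthalen-1-yl, whereas this result shows that single-ring groups can also differ clearly from one another at this place, with pyridin-2-yl lying above both 3-(trifluoromethyl)phenyl and 3,4-dichlorophenyl. Nothing available accounts for this rise.

The change removes a second aromatic ring and brings in a ring nitrogen with a hydrogen-bond acceptor, and the compounds shown do not separate these two parts of the change. A plain phenyl group or a quinoline ring at this place would bear on that question.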